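This account rests on a few compounds, and the source may have more. Where it says the series, first, only, none or still open, it means among the compounds named here.

Measured compounds:
Compound 1, `CC(C)c1nn(-c2ccc(C(N)=O)c(N[C@H]3CC[C@H](O)CC3)c2)c2nccc(-n3cnc(-c4ccncc4)c3)c12`: in a functional assay on SK-BR-3 cells (Homo sapiens) for inhibition, read by CellTiter-Glo, with a stated time of 72 h (a higher number here means a weaker inhibitor, a lower number a stronger inhibitor), compound 1 gives 165 nM.
Compound 2, `CC(C)c1nn(-c2ccc(C(N)=O)c(N[C@H]3CC[C@H](O)CC3)c2)c2nccc(-c3ccoc3)c12`: in this assay compound 2 gives only a limit, > 10000 nM, (the limit of > 10000 nM in this assay, at which 1 of the 2 values shown sits).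

Compound 2 thus stands at the weak end of what is shown, as a limit rather than a number. Compound 3, `CC(C)c1nn(-c2ccc(C(N)=O)c(N[C@H]3CC[C@H](O)CC3)c2)c2nccc(-n3cnc(-c4ccccc4)c3)c12`, differs from compound 2 by 4-phenyl-1H-imidazol-1-yl in place of furan-3-yl on an aromatic carbon. For the measured compounds named here, the one measured step that bears on this change is an at least 60-fold higher number from compound 1 to compound 2 (1.78 log units; beyond the scatter), and the change to compound 3 runs largely in the reverse structural direction, toward a group close to that of compound 1. A large step to a lower number is therefore expected, an at least 33-fold lower number from compound 2 to compound 3 (1.52 log units; beyond the scatter). Compound 3 is expected at 300 nM, in the range 100 nM to 2000 nM.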

Compound 3, half-maximal inhibitory concentration: 276 nM
Compound 3: the middle estimate sits 1.1-fold (0.04 log units) above what was measured; measured number inside the range.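

The 4-phenyl-1H-imidazol-1-yl group in place of furan-3-yl on this aromatic carbon gives an at least 36-fold lower number from compound 2 to compound 3 (1.55 log units; beyond the scatter). Compound 2 is held at a limit, so that step is a bound and not an exact size: the limit of > 10000 nM in this assay, at which 1 of the 3 values shown sits. Phenyl in place of pyridin-4-yl gives a 1.7-fold higher number from compound 1 to compound 3 (0.22 log units; within the scatter), so the outer ring of this group need not hold a nitrogen to keep the number in this assay.

Open is how far the imidazole ring alone accounts for the step, as an unsubstituted 1H-imidazol-1-yl group is not among the compounds shown. Also open, on these data alone, is how an amine or a carboxylic acid on the phenyl ring would read.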